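This account rests on a few compounds, and the source may have more. Where it says the series, first, only, none or still open, it means among the compounds named here.

The three compounds share one core. Compound 1 is `O=c1c(CSC(=S)N2CCCC2)coc2ccccc12`, compound 2 is `COc1ccc2occ(CSC(=S)N3CCOCC3)c(=O)c2c1`, and compound 3, still to be measured, is `COc1ccc2occ(CSC(=S)N3CCCC3)c(=O)c2c1`. The single measure is a functional assay on HeLa cells (Homo sapiens) for antiproliferative activity, read by MTT assay, with a stated time of 72 h; a higher number here means a weaker inhibitor, a lower number a stronger inhibitor. For compound 1 the report is a limit of the assay, not a number: in this assay compound 1 gives > 25000 nM. That ceiling is the limit of > 25000 nM in this assay, at which 1 of the 2 values shown sits. In this assay, going by the values given here, compound 2 gives 9500 nM, the only real number among the two values shown. The other value belongs to compound 1 and is a limit of the assay, so compound 2 stands alone rather than ranked. Among the compounds with values here, compound 1 and compound 2 differ in two places, and no single step joins them. Compound 2 and compound 3 differ in one place: pyrrolidin-1-yl in place of morpholin-4-yl on a thiocarbonyl carbon. Within the data shown here, no measured step of this kind exists here, so the expectation rests on compound 2 at 9500 nM. Compound 1 returned only a limit of the assay. The step from compound 2 to compound 3 in this assay is expected to be modest and toward weaker inhibition, a 1.6-fold higher number from compound 2 to compound 3 (0.20 log units; within the scatter). For compound 3 in this assay the estimate is 15000 nM, between 5000 nM and 40000 nM.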

Compound 3, half-maximal inhibitory concentration: 12100 nM
Estimate against measurement, compound 3: 1.2-fold (0.09 log units) above; measured number inside the range.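

In this assay, pyrrolidin-1-yl in place of morpholin-4-yl on a thiocarbonyl carbon can now be read directly, as a 1.3-fold higher number from compound 2 to compound 3 (0.11 log units; within the scatter), so with methoxy on the core this exchange of one ring for the other does not separate compound 2 from compound 3. The second comparison gives the first single-place reading on the aromatic part of the core: methoxy in place of hydrogen on an aromatic carbon gives an at least 2.0-fold lower number from compound 1 to compound 3 (0.31 log units; beyond the scatter), which lies beyond the scatter and is the only change shown that does so. Compound 1 gives a limit of the assay rather than a number, so the size of this step is only a bound and its true size stays unknown: the limit of > 25000 nM in this assay, at which 1 of the 3 values shown sits.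

The compounds shown leave open how an open-chain amine such as diethylamino, or a piperazin-1-yl ring, would read on the thiocarbonyl carbon. They also leave open whether a chloro or hydroxy group on that aromatic carbon would give a similar step to methoxy.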